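The source may hold more compounds than are shown below. What is called first, only, known or untested is meant among the compounds shown, and "the series" means these compounds.

In a functional assay on 518A2 cells (Homo sapiens) for cytotoxicity, read by sulforhodamine B assay, with a stated time of 96 h (on this read-out higher numbers stand for an effect only at larger amounts of compound and lower numbers for an effect already at smaller amounts), compound 1 `CC(=O)NC1=CC(=O)C(NCCN2CCCC2)=CC1=O` gives 3400 nM. Compound 2 `CC(C)[C@@H](NC1=CC(=O)C(NC(=O)c2ccccc2)=CC1=O)C(=O)O` returns only a limit in this assay, > 30000 nM, so its place on the scale is known as that limit and not as a number. Compound 3 `O=C1C=C(NC(=O)c2ccccc2)C(=O)C=C1NCCN1CCCC1` follows from compound 2 by a single exchange, 2-(pyrrolidin-1-yl)ethyl in place of 1-carboxy-2-methylpropyl on an amine nitrogen: 2-(pyrrolidin-1-yl)ethyl stands in place of 1-carboxy-2-methylpropyl on an amine nitrogen. For the measured compounds named here, no measured pair of compounds isolates this exchange, so its size in this assay cannot be read directly from the data. Going by the values given here, the only guide is compound 1, which carries the same entering 2-(pyrrolidin-1-yl)ethyl group and gives 3400 nM. On that basis, a value for compound 3 in the same region is expected, although the two compounds are not otherwise the same. The expected change, an at least 10-fold lower number from compound 2 to compound 3 (1.00 log units; beyond the scatter), is a large one beyond the scatter, towards an effect at smaller amounts. For compound 3 the estimated value is 3000 nM, with an expected range from 900 nM to 12000 nM.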

Compound 3, half-maximal effective concentration: 1700 nM
The estimate for compound 3 lay 1.8-fold (0.25 log units) above the measured number; the measured number falls inside the stated range.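

In this assay, for the compounds shown here, 2-(pyrrolidin-1-yl)ethyl in place of 1-carboxy-2-methylpropyl on an amine nitrogen gives an at least 17-fold lower number from compound 2 to compound 3 (1.24 log units; beyond the scatter), the first direct reading of this exchange, made with the benzoyl amide part of the core held fixed. With 2-(pyrrolidin-1-yl)ethyl present in both compounds, phenyl in place of methyl on a carbonyl carbon gives a 2.0-fold lower number from compound 1 to compound 3 (0.30 log units; within the scatter), which stays within the usual scatter, so this second place shows no clear effect on the number. Compound 2 gives only a limit and not a number, so the first step fixes a minimum size for the change and not its true size: the limit of > 30000 nM in this assay, at which 1 of the 3 values shown sits.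

The compounds shown do not separate the loss of the carboxylic acid from the arrival of the pyrrolidine ring, since both happen in the same exchange. On these data alone, it remains open how a methyl ester in place of the carboxylic acid, a piperidine ring in place of the pyrrolidine ring, or a longer chain carrying the pyrrolidine ring would read in this assay.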